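Hydroxy to Amino, Repeated on a Second Core

The source may hold more compounds than are shown below. What is called first, only, known or untested is meant among the compounds shown, and "the series" means these compounds.

Compound 1, `COc1ccc(-c2cc3ccccc3c(-c3cccc(O)c3)n2)cc1`, gives 580 nM in a functional assay on T47D cells (Homo sapiens) for cytotoxicity, read by CCK-8 assay and cell counting, with a stated time of 72 h; on this read-out higher numbers stand for weaker inhibition and lower numbers for stronger inhibition.
Compound 2, `COc1ccc(-c2cc3ccccc3c(-c3cccc(N)c3)n2)cc1`, gives 950 nM in this assay.
Compound 3, `COc1ccc(-c2cc3cc(C)ccc3c(-c3cccc(O)c3)n2)c(C)c1`, gives 560 nM in this assay.

Compound 1 and compound 3 differ in their cores, and that difference is not broken down here. From compound 1 to compound 2 the change is amino in place of hydroxy on an aromatic carbon, and it gave a 1.6-fold higher number from compound 1 to compound 2 (0.21 log units; within the scatter). Compound 4, `COc1ccc(-c2cc3cc(C)ccc3c(-c3cccc(N)c3)n2)c(C)c1`, carries the same change on the core of compound 3: amino in place of hydroxy on an aromatic carbon. The place of the change is the same in both pairs, so this is the same change made twice. Because the first pair gave a 1.6-fold higher number from compound 1 to compound 2 (0.21 log units; within the scatter), a step of similar size is expected for the second pair, namely a 1.6-fold higher number from compound 3 to compound 4 (0.21 log units; within the scatter). Compound 4 is therefore estimated at 900 nM in this assay, with a range from 450 nM to 1800 nM.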

Compound 4, half-maximal inhibitory concentration: 740 nM
Compound 4: middle estimate off by 1.2-fold (0.09 log units), on the high side; the measured number falls inside the stated range.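

In this assay, putting amino in place of hydroxy on the core of compound 3 gave a 1.3-fold higher number from compound 3 to compound 4 (0.12 log units; within the scatter). Set beside the same change on the core of compound 1, the two steps agree: the same change on two cores in this assay, a 1.6-fold higher number (0.21 log units; within the scatter) from compound 1 to compound 2 and a 1.3-fold higher number (0.12 log units; within the scatter) from compound 3 to compound 4, 1.2-fold (0.09 log units) apart, within the scatter of two such steps. This shows that the change behaved alike on these two cores, but with both steps inside the scatter, it does not show that amino and hydroxy truly differ here, and two cores cannot show how the change will behave on a third.

The compounds shown leave open whether a different group at this place, such as a carboxylic acid or an amide, would give a step beyond the scatter.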